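The compounds below may be only part of what the source reports. "The series", "measured", "known", "first", "only" and "open" are said of these compounds alone.

Compound 1 `O=C(CCCCC1CCSS1)Nc1ccccn1`: "not active" (no number reported)
Compound 2 `O=C(CCCCC(S)CCS)Nc1cccc(Cl)c1`: "not active" (no number reported)
Compound 3 `O=C(CCCCC(S)CCS)Nc1ccc(Cl)cc1`: 22%

In a functional assay on NCI-H460 cells (Homo sapiens) for inhibition, read by MTT assay, with a stated time of 24 h, tested at 10 ug/mL (a higher number here means more inhibition of growth at the concentration tested, a lower number less inhibition of growth), compound 3, at 22%, is the only one of the three with a number, since compound 1 and compound 2 were reported without one. Compound 4 `O=C(CCCCC(S)CCS)Nc1ccc([N+](=O)[O-])cc1` differs from compound 3 in a single place, with nitro in place of chloro on an aromatic carbon, para to a large group: nitro in place of chloro on an aromatic carbon. Going by the values given here, no measured pair shows what this exchange does, so no direction can be read from the data, and no step beyond the scatter is expected in this assay. The expected step is a number 2 percentage points lower from compound 3 to compound 4 (within the scatter). For compound 4 the estimated value is 20%, with an expected range of 5% to 40%.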

Compound 4, percent growth inhibition at one concentration: 13.4%
For compound 4 the middle estimate is 6.6 percentage points above the measured one; low and high end bracket the measured number.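

In this assay, going by these compounds alone, nitro in place of chloro on the aromatic carbon, para to a large group, gives a number 8.6 percentage points lower from compound 3 to compound 4 (within the scatter) and so offers the first comparison of compounds differing in one place. At this position, the larger nitro group leaves growth inhibition within the scatter of the chloro compound. Nothing available gives a reason for this result.

Still open, as far as these compounds go, is whether an amine or a carboxylic acid at this position would move the number beyond the scatter.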